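Compound 3: trifluoromethoxy in place of methyl

This account rests on a few compounds, and the source may have more. Where it says the series, first, only, none or still open, it means among the compounds named here.

Compound 1 `COc1ccc(-n2cnc3cnc(Nc4cccc(NC(C)=O)c4)cc32)cc1OC` and compound 2 `COc1ccc(-n2cnc3cnc(-c4ccccc4C)cc32)cc1OC` share a core. In a physicochemical assay for solubility (on this read-out higher numbers stand for higher solubility and lower numbers for lower solubility), compound 1 gives > 200000 nM as a limit and not a number. Compound 2 gives > 200000 nM as a limit too, so its place on this read-out is known only as a limit.

Compound 3 `COc1ccc(-n2cnc3cnc(-c4ccccc4OC(F)(F)F)cc32)cc1OC` has trifluoromethoxy in place of methyl on an aromatic carbon ortho to a large group. No measured step sizes this change, and no shift beyond the scatter is expected in this assay for it. The expected step is an at least 1.3-fold lower number from compound 2 to compound 3 (0.12 log units; that floor lies within the scatter) and another limit reading is possible. For compound 3 the estimate is 150000 nM with an expected range from 40000 nM to 300000 nM on this read-out.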

Compound 3, solubility: 157000 nM
Compound 3: the middle estimate sits 1.0-fold (0.02 log units) below what was measured; the measured number falls inside the stated range.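

Within the data shown here, compound 3 gives the only reading in this assay here that is a number and not a limit, so this place, on an aromatic carbon ortho to a large group, now has one measured value. Trifluoromethoxy in place of methyl reads as an at least 1.2-fold lower number from compound 2 to compound 3 (0.10 log units; that floor lies within the scatter). That step remains a floor, with its full size unknown, because of where compound 2 sits: the limit of > 200000 nM in this assay, at which 2 of the 3 values shown sit.

Open, as far as these compounds go, is how an amine or a carboxylic acid on this same carbon would read. Also open, from the compounds shown here alone, is whether any group here gives a step beyond the scatter.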